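The source may hold more compounds than are shown below. What is called first, only, known or untested is meant among the compounds shown, and "the series" means these compounds.

Measured in an ADME assay on PANC-1 cells (Homo sapiens) for cytotoxicity, read by sulforhodamine B assay, with a stated time of 48 h, tested at 10 uM; a lower number here means less inhibition, a higher number more inhibition at the concentration tested (going by the name of the read-out):
compound 1 `CCCc1cn(C(c2ccccc2)c2cc3cc(Br)ccc3nc2OC)nn1` gives 11.3%;
compound 2 `COc1nc2ccc(Br)cc2cc1C(c1ccccc1)n1cc(CCO)nn1` gives 19.8%;
compound 3 `COc1nc2ccc(Br)cc2cc1C(c1ccccc1)n1cc(-c2cccc(F)c2)nn1` gives 15.5%.

Compound 3 stands second highest of the three numbers. Its nearest neighbour is compound 1, with a number 4.2 percentage points higher from compound 1 to compound 3 (within the scatter), and its furthest is compound 2, with a number 4.3 percentage points lower from compound 2 to compound 3 (within the scatter); both steps lie within the scatter, so the three measured compounds cannot be told apart on these numbers.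

Compound 4 `COc1nc2ccc(Br)cc2cc1C(c1ccccc1)n1cc(CCCCCO)nn1` has not yet been measured. It differs from compound 3 in one place: 5-hydroxypentyl in place of 3-fluorophenyl on an aromatic carbon. The step that bears most directly on this is a number 4.3 percentage points lower from compound 2 to compound 3 (within the scatter), which exchanged a short hydroxyalkyl chain for the same 3-fluorophenyl group and stayed within the scatter. The step of a number 4.2 percentage points higher from compound 1 to compound 3 (within the scatter), replacing propyl with 3-fluorophenyl, was also within the scatter, and a number 8.5 percentage points higher from compound 1 to compound 2 (within the scatter) shows that adding a hydroxy to the chain moved the number only within the scatter. Compound 4 is therefore expected to show no step beyond the scatter, with the estimated change a number 1.5 percentage points higher from compound 3 to compound 4 (within the scatter) leaning slightly higher. The estimate for compound 4 is 17%, between 7% and 28%.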

Compound 4, a percentage reported as inhibition, at one concentration (the size of the read-out at that concentration, not a potency): 19.6%
The estimate for compound 4 lay 2.6 percentage points below the measured number; the measured number falls inside the stated range.
By their numbers in this assay, from the lowest: compounds 1, 3, 4 and 2 (each within the scatter of the next).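

In this assay the position on the five-membered aromatic ring with 3 nitrogen accepts 5-hydroxypentyl, a chain with no ring, in place of 3-fluorophenyl with only a small step, a number 4.1 percentage points higher from compound 3 to compound 4 (within the scatter) and so within the scatter. Set against the shorter hydroxy chain of compound 2, the 5-hydroxypentyl chain gives a number 0.2 percentage points lower from compound 2 to compound 4 (within the scatter) and, set against the propyl of compound 1, it gives a number 8.3 percentage points higher from compound 1 to compound 4 (within the scatter) so neither comparison separates the compounds. Across propyl, 2-hydroxyethyl, 5-hydroxypentyl and 3-fluorophenyl, no group at this position has moved the number beyond the scatter at the single concentration tested. No evidence bears on why these numbers fall as they do. As far as these compounds go, whether an amine, a carboxylic acid or a longer chain in this place would move the number beyond the scatter remains open.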